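Working notes: methoxy analogue of compound 3

This account rests on a few compounds, and the source may have more. Where it says the series, first, only, none or still open, it means among the compounds named here.

Measured so far:
compound 1 `Nc1cccc(-c2cn3nc(Cc4ccc(Cl)cc4)sc3n2)c1`, 16000 nM
compound 2 `Nc1cccc(-c2cn3c(-c4ccccc4)csc3n2)c1`, 85000 nM
compound 3 `C=C(Br)C(=O)Nc1cccc(-c2cn3c(-c4ccccc4)csc3n2)c1`, 1300 nM

All three numbers come from a functional assay on L1210 cells (Mus musculus) for inhibition, read by cell counting, with a stated time of 2 days; a higher number here means a weaker inhibitor, a lower number a stronger inhibitor. Compound 1 and compound 2 share the free aniline nitrogen and differ in the substituent on the shared core; the two values show compound 2 giving the higher number. Among the compounds with values here, the only single-point step measured is a 65-fold lower number from compound 2 to compound 3 (1.82 log units; beyond the scatter), the acylation of the aniline nitrogen with the (1-bromoethenyl)carbonyl group. Compound 3 therefore gives the lowest number of the three in this assay, and its nearest neighbour in value is compound 1.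

The next compound is compound 4 `C=C(Br)C(=O)Nc1cccc(-c2cn3c(-c4ccc(OC)cc4)csc3n2)c1`. It differs from compound 3 by methoxy in place of hydrogen on an aromatic carbon, that is, the phenyl on the shared core becomes 4-methoxyphenyl while the (1-bromoethenyl)carbonyl amide is kept.

Within the data shown here, no measured step touches the phenyl ring; the one large step measured concerns the aniline nitrogen and does not bear on a methoxy on the distal ring. With the amide retained, no step beyond the scatter is expected in this assay; the expected step is no change at the digits printed from compound 3 to compound 4 (within the scatter). Compound 4 is therefore estimated at 1300 nM, with a range from 500 nM to 3500 nM.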

Compound 4, half-maximal inhibitory concentration: 200 nM
Compound 4: middle estimate off by 6.5-fold (0.81 log units), on the high side; the whole stated range lies above it.
By their numbers in this assay, from the lowest: compound 4; then compound 3; then compound 1; then compound 2.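

In this assay the phenyl on the shared core proves to be a position that responds: with the (1-bromoethenyl)carbonyl amide held fixed, methoxy in place of hydrogen gives a 6.5-fold lower number from compound 3 to compound 4 (0.81 log units; beyond the scatter) and so moves the number by more than the scatter. The earlier compounds shown here showed a single-point change only at the aniline nitrogen, where the step is a 65-fold lower number from compound 2 to compound 3 (1.82 log units; beyond the scatter) and is rated large against the modest rating of the new step, so the series now has two places where one change alters the read-out. Nothing at hand explains why 4-methoxyphenyl gives the lower number.

The compounds shown carry only one substituent on this ring, so it remains open whether the step is particular to methoxy or would also appear with a chlorine, a hydroxyl, an amine or a longer chain such as ethoxy on the same carbon. Also open, from the compounds shown here alone, is whether 4-methoxyphenyl gives a similar step on the free aniline, without the (1-bromoethenyl)carbonyl amide.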